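The source may report more compounds than this note shows. Statements on the series, on what has been measured and on what is new or still open speak of the compounds shown alone.

Measured so far:
compound 1 `CCCCCCCCCCC(=O)NCC(C)(C)CC1=C(O)C(=O)c2ccccc2C1=O` gives 17600 nM in a functional assay on KB cells (Homo sapiens) for cytotoxicity, read by resazurin assay, with a stated time of 3 days; a higher number here means a weaker inhibitor, a lower number a stronger inhibitor
compound 2 `CCCCCCCCCCCC(=O)NCC(C)(C)CC1=C(O)C(=O)c2ccccc2C1=O` gives 12800 nM in this assay
compound 3 `CCCCCCCCC(=O)OCC(C)(C)CC1=C(O)C(=O)c2ccccc2C1=O` gives 38700 nM in this assay

Compounds 1 and 2 share one core and differ in a single place, (methyl in place of hydrogen on a saturated chain carbon, ten or more bonds along the chain from a carbonyl carbon). That change made a step of a 1.4-fold lower number from compound 1 to compound 2 (0.14 log units; within the scatter). Compound 3 carries a different core; the difference between the two cores is not broken down here. Compound 3 stands at the highest number of the three, compound 1 nearest to it and compound 2 furthest.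

Compound 4 `CCCCCCCCCC(=O)OCC(C)(C)CC1=C(O)C(=O)c2ccccc2C1=O` is not yet measured in this assay. It differs from compound 3 by methyl in place of hydrogen on a saturated chain carbon, eight bonds along the chain from a carbonyl carbon. Within the data shown here, this is the same kind of change as the one from compound 1 to compound 2, but the entering methyl sits at a different place on the chain relative to the carbonyl carbon. A step of similar size is expected, a 1.3-fold lower number from compound 3 to compound 4 (0.11 log units; within the scatter), resting on the earlier step of a 1.4-fold lower number from compound 1 to compound 2 (0.14 log units; within the scatter), which stayed within the scatter. Compound 4 is therefore estimated at 30000 nM in this assay, with a likely range of 15000 nM to 60000 nM.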

Compound 4, half-maximal inhibitory concentration: 55500 nM
Compound 4: middle estimate off by 1.9-fold (0.27 log units), on the low side; the measured number falls inside the stated range.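

In this assay methyl in place of hydrogen on a saturated chain carbon, eight bonds along the chain from a carbonyl carbon, makes a 1.4-fold higher number from compound 3 to compound 4 (0.16 log units; within the scatter) and this stands with the earlier step on the other core: the same change on two cores in this assay, a 1.4-fold lower number (0.14 log units; within the scatter) from compound 1 to compound 2 and a 1.4-fold higher number (0.16 log units; within the scatter) from compound 3 to compound 4, 2.0-fold (0.29 log units) apart, within the scatter of two such steps. Neither step lies beyond the scatter and the two do not differ beyond it, so on these two pairs the change carries from one core to the other as a change of no readable size, and no direction can be read from either step. This does not show that the methyl is without effect elsewhere or on other cores, and the entering methyl sits at a different place on the chain in each pair, so core and place are not separated.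

As far as these compounds go, whether a longer chain on either core would give a step beyond the scatter stays open. Also open, from the compounds shown here alone, is what a chain carrying an amine or a carboxylic acid would give on these cores.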